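The source may report more compounds than this note shows. Statements on the series, on what has been measured and on what is new or still open speak of the compounds shown alone.

Compound 3 `COCC1CCN(c2c(S(=O)(=O)c3cc(F)cc(F)c3)cnc3cc(F)ccc23)CC1` gives 83% in an assay on isolated protein for displacement of a labelled ligand from metabotropic glutamate receptor 5 (Homo sapiens), with a stated time of 60 min, tested at 1 uM; on this read-out lower numbers stand for less inhibition and higher numbers for more inhibition at the one concentration tested (going by the name of the read-out). Its number sits between the other two measured ones. Compound 1 `COCC1CCN(c2c(S(=O)(=O)c3ccc(F)cc3)cnc3cc(F)ccc23)CC1` gives 76.1% in this assay, and the one-place step a number 6.9 percentage points higher from compound 1 to compound 3 (within the scatter) is within the scatter. Going by the values given here, compound 2 `COc1ccc2ncc(S(=O)(=O)c3ccc(C)cc3)c(N3CCC(C)CC3)c2c1` gives 90% in this assay; no single-place step connects it to compound 3, and the gap between the two numbers is within the scatter, so the three measured compounds are not separated from one another on this read-out.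

Compound 4 `NS(=O)(=O)N1CCN(c2c(S(=O)(=O)c3cc(F)cc(F)c3)cnc3cc(F)ccc23)CC1` differs from compound 3 at one place: 4-sulfamoylpiperazin-1-yl in place of 4-(methoxymethyl)piperidin-1-yl on an aromatic carbon. Among the compounds with values here, the only measured step, a number 6.9 percentage points higher from compound 1 to compound 3 (within the scatter), alters the aryl group on the sulfonyl sulfur and leaves the ring on the aromatic carbon untouched, so it says nothing directly about the change to compound 4. Compound 2 differs from compound 3 in several places at once and does not isolate this position. Within the data shown here, no measured step therefore bears on the replacement, and the expectation rests on the observation that all three measured numbers lie close together in this assay. The expected step is a number 9 percentage points lower from compound 3 to compound 4 (within the scatter), with no direction favoured beyond the scatter. Compound 4 is expected to give 74% in this assay, with a range from 45% to 92%.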

Compound 4, a percentage reported as inhibition, at one concentration (the size of the read-out at that concentration, not a potency): 6.4%
Estimate against measurement, compound 4: 67.6 percentage points above, and the stated range ends above it.
By their numbers in this assay, from the lowest: compound 4; then compounds 1, 3 and 2 (each within the scatter of the next, the first and the last beyond it).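

Going by these compounds alone, the place on the aromatic carbon opposite the ring nitrogen is not indifferent in this assay: exchanging 4-(methoxymethyl)piperidin-1-yl for 4-sulfamoylpiperazin-1-yl gives a number 76.6 percentage points lower from compound 3 to compound 4 (beyond the scatter), a large change, whereas the one earlier step, a number 6.9 percentage points higher from compound 1 to compound 3 (within the scatter), altered only the aryl group on the sulfonyl sulfur. Compound 1 and compound 3 carry the same group at this place, so their close numbers gave no reading of it, and the new step shows that this place does not accept every six-membered non-aromatic ring. The data give no account of the loss, and nothing available bears on its origin.

The exchange alters the ring hetero atoms and adds the sulfamoyl group in a single step, so the two remain unseparated; an unsubstituted piperazin-1-yl or a piperazine carrying an acetyl group on the same nitrogen would tell them apart. Going by these compounds, whether the same exchange has a comparable effect alongside the 4-fluorophenyl group of compound 1 also remains open.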